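The source may hold more compounds than are shown below. What is called first, only, known or untested is meant among the compounds shown, and "the series" means these compounds.

Measured compounds:
compound 1, `CC(C)(C)Cc1nn(CCC2CC2)c(=O)c(C2=NS(=O)(=O)c3cc(NS(C)(=O)=O)ccc3N2)c1O` — > 1000 nM
compound 2, `CC(C)(C)CCn1nc(CC(C)(C)C)c(O)c(C2=NS(=O)(=O)c3cc(NS(C)(=O)=O)ccc3N2)c1=O` — > 1000 nM

In an ADME assay on Huh-7 cells (Homo sapiens) for cytotoxicity, with a stated time of 72 h (on this read-out higher numbers stand for lower toxicity in this test and lower numbers for higher toxicity in this test), compound 1 gives only a limit of the test, > 1000 nM. Compound 2 likewise gives only a limit in this assay, > 1000 nM. Going by the values given here, the one measured pair, tert-butyl in place of cyclopropyl on a saturated chain carbon, two bonds along the chain from an aromatic nitrogen, yields a step that cannot be read: a step that the two limits leave unreadable from compound 1 to compound 2. Both values sit at the same point, (the limit of > 1000 nM in this assay, at which 2 of the 2 values shown sit), so compound 2 stands at that limit and nowhere more precisely than that.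

Compound 3, `CC(C)=Cc1nn(CCC(C)(C)C)c(=O)c(C2=NS(=O)(=O)c3cc(NS(C)(=O)=O)ccc3N2)c1O`, differs from compound 2 by 2-methylprop-1-en-1-yl in place of neopentyl on an aromatic carbon. Among the compounds with values here, no measured step in this assay touches that position, and the single step that was measured is unreadable, so nothing measured here gives a direction or a size for the change from compound 2 to compound 3. Compound 3 is therefore expected to sit at the same limit, with the step of a number no higher from compound 2 to compound 3 (the limit leaves the size open) expected to be none beyond the scatter. The estimate for compound 3 is 1000 nM, with a range from 500 nM to 2000 nM.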

Compound 3, half-maximal cytotoxic concentration: > 1000 nM
Compound 3: only a limit was reported; the forecaster's own chance of this, stated with the estimate: 85%; the middle value sits exactly at the limit.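

In this assay compound 3 gives only a limit, > 1000 nM. Compound 2 also gives only a limit, so the step between compound 2 and compound 3 cannot be read. The compounds shown leave open at what concentration compound 1, compound 2 or compound 3 would become toxic to these cells, and whether 2-methylprop-1-en-1-yl in place of neopentyl shifts that concentration.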